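Chloro in Place of Methoxy on the Benzyl Ether

A few compounds are considered here, and "the series" means these few. Any claim that something is new, unique, unknown or untested is made for them only; others in the source may bear on it.

Of the compounds shown here, three built on a shared core have been tested in an assay on SK-BR-3 cells for inhibition of Aromatase (Homo sapiens); a lower number here means a stronger inhibitor, a higher number a weaker inhibitor. Compound 1 `CS(=O)(=O)Nc1ccc([N+](=O)[O-])cc1OCc1ccc([N+](=O)[O-])cc1` gives 400 nM. Compound 2 `CS(=O)(=O)Nc1ccc([N+](=O)[O-])cc1OCc1ccc2ccccc2c1` gives 2170 nM. Compound 3 `COc1ccc(COc2cc([N+](=O)[O-])ccc2N(C)S(C)(=O)=O)cc1` gives 470 nM, the second highest of the three numbers: it sits so close to compound 1 that the two lie within the usual scatter, while compound 2 gives a number higher than that of compound 3 by a margin beyond the scatter.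

Compound 4 `CN(c1ccc([N+](=O)[O-])cc1OCc1ccc(Cl)cc1)S(C)(=O)=O` has not yet been measured. It differs from compound 3 in one place only: chloro in place of methoxy on an aromatic carbon. Going by the values given here, no measured pair shows what this exchange does on its own, so the expectation rests on compound 1 and compound 3, which differ in more than one place yet give numbers within the scatter of each other. The expected step is therefore modest, a 1.3-fold lower number from compound 3 to compound 4 (0.13 log units; within the scatter), within the scatter, with a slight lean toward a lower number. Compound 4 is estimated at 350 nM, with a likely range from 120 nM to 1000 nM.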

Compound 4, half-maximal inhibitory concentration: 2400 nM
Estimate against measurement, compound 4: 6.9-fold (0.84 log units) below; the whole stated range lies below it.
By their numbers in this assay, from the lowest: compounds 1 and 3 (each within the scatter of the next); then compounds 2 and 4 (each within the scatter of the next).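

On the ring of the benzyl ether, at the carbon para to a large group, the swap of methoxy for chloro in this assay gives a 5.1-fold higher number from compound 3 to compound 4 (0.71 log units; beyond the scatter) and so makes a clearly weaker inhibitor. This position is therefore not indifferent to what sits on it: a change of a single small group, with every other part of the molecule the same, is enough to move the number beyond the scatter. The size of the step is all that is known, as nothing available accounts for it.

Still open, from the compounds shown here alone, is which feature of methoxy matters, something a hydroxy, methyl or fluoro group at the same carbon could help to separate. Also open, going by these compounds, is whether a longer chain such as ethoxy or propoxy would hold the number of compound 3 or lose it too.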